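The compounds below may be only part of what the source reports. "The series", "measured", "known", "first", "only" and "open" are said of these compounds alone.

Measured in a functional assay for inhibition, with Homo sapiens as the target; a lower number here means tighter binding, a higher number weaker binding:
- compound 1 `O=C(O)CC/C=C\CC1COC(c2ccccc2Cl)OC1c1cccnc1`: 759 nM
- compound 2 `N#Cc1ccccc1C1OCC(C/C=C\CCC(=O)O)C(c2cccnc2)O1`: 245 nM

Compound 2 has the lower of the two numbers, 245 nM. Next is compound 3 `O=C(O)CC/C=C\CC1COC(c2ccc([N+](=O)[O-])cc2)OC1c1cccnc1`, with 4-nitrophenyl in place of 2-cyanophenyl on a saturated ring carbon, between two ring oxygen atoms: 4-nitrophenyl in place of 2-cyanophenyl on a saturated ring carbon. Going by the values given here, the only measured step, a 3.1-fold lower number from compound 1 to compound 2 (0.49 log units; beyond the scatter), is modest and beyond the scatter; it swaps cyano for chloro on that same aryl group. Among the compounds with values here, no measured compound carries 4-nitrophenyl, so this is weak guidance. A modest rise in this assay is expected, a 2.2-fold higher number from compound 2 to compound 3 (0.35 log units; beyond the scatter). The estimate for compound 3 is 550 nM, with an expected range of 170 nM to 1800 nM.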

Compound 3, dissociation constant: 933 nM
Beside the measured number, compound 3's estimate is 1.7-fold (0.23 log units) below it, and the stated range covers the measured number.
By their numbers in this assay, from the lowest: compound 2; then compounds 1 and 3 (each within the scatter of the next).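

On the saturated ring carbon between two ring oxygen atoms, 4-nitrophenyl does not keep the level of 2-cyanophenyl in this assay, with a 3.8-fold higher number from compound 2 to compound 3 (0.58 log units; beyond the scatter), and it stays level with 2-chlorophenyl, with a 1.2-fold higher number from compound 1 to compound 3 (0.09 log units; within the scatter). Of the three aryl groups at this position, only 2-cyanophenyl stands apart, and no measurement on hand accounts for that.

Compound 3 changes both the substituent and its place on the phenyl ring, so these two changes stay unseparated. Open, as far as these compounds go, are 4-cyanophenyl and 2-nitrophenyl, which would separate them, and unsubstituted phenyl as a reference.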